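Swapping the Indole Amine of a Weak Cell Inhibitor

A few compounds are considered here, and "the series" means these few. Any claim that something is new, unique, unknown or untested is made for them only; others in the source may bear on it.

Compound 1 `Cn1c(=O)c(S(=O)(=O)c2ccc(F)cc2)cc2cnc(Nc3ccc4cc[nH]c4c3)nc21` gives 10000 nM in a functional assay on DU-145 cells (Homo sapiens) for inhibition, read by trypan blue exclusion, with a stated time of 72 h; a lower number here means a stronger inhibitor, a higher number a weaker inhibitor.
Compound 2 `Cn1c(=O)c(S(=O)(=O)c2ccc(F)cc2F)cc2cnc(Nc3ccc4cc[nH]c4c3)nc21` gives 5000 nM in this assay.

Within the data shown here, compound 1 stands at the highest of the two numbers measured so far. Its nearest neighbour is compound 2, and the step of a 2.0-fold lower number from compound 1 to compound 2 (0.30 log units; within the scatter) lies within the scatter, so the two values show no difference that can be read as an order of potency.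

Compound 3 `Cn1c(=O)c(S(=O)(=O)c2ccc(F)cc2)cc2cnc(Nc3cnc4[nH]ccc4c3)nc21` has not yet been measured. It differs from compound 1 in one place: a group of 9 heavy atoms (7 carbon, 2 nitrogen; one five-membered aromatic ring with 1 hetero atom, one six-membered aromatic ring with 1 hetero atom) in place of a group of 9 heavy atoms (8 carbon, 1 nitrogen; one five-membered aromatic ring with 1 hetero atom, one six-membered aromatic ring of carbon only), on a nitrogen on an aromatic ring. Among the measured compounds shown here, no measured step concerns this kind of change. For the measured compounds named here, the only step known, a 2.0-fold lower number from compound 1 to compound 2 (0.30 log units; within the scatter), comes from a fluoro in place of hydrogen on an aromatic carbon, a change in a different part of the molecule, and it was itself within the scatter. There is therefore nothing in the data that points to a shift in either direction for compound 3, and the expectation is no step beyond the scatter.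

On that basis compound 3 is estimated at 10000 nM in this assay, with a range of 3000 nM to 30000 nM, which corresponds to an expected step of no change at the digits printed from compound 1 to compound 3 (within the scatter).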

Compound 3, half-maximal inhibitory concentration: 500 nM
Compound 3: the middle estimate sits 20-fold (1.30 log units) above what was measured; the measured number lies below the stated range.
By their numbers in this assay, from the lowest: compound 3; then compounds 2 and 1 (each within the scatter of the next).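

In this assay, the group on the nitrogen on an aromatic ring proves to be a place where the read-out responds strongly: exchanging 1H-indol-6-yl for a group with the same count of 9 heavy atoms, but with 2 nitrogen rather than 1 and a hydrogen-bond acceptor that the indolyl group lacks, gives a 20-fold lower number from compound 1 to compound 3 (1.30 log units; beyond the scatter). Among these compounds, the earlier fluoro change gave only a 2.0-fold lower number from compound 1 to compound 2 (0.30 log units; within the scatter), so this is the first step that can be read as a real change, and it shows that a swap leaving the size of the group unchanged can still move the number by a large margin. The data at hand offer nothing that accounts for this step.

Whether the same exchange would carry over to the difluorinated compound 2 remains open, since the step is shown only on the background of compound 1. Also open, on these data alone, is how other groups would fare at this place, such as a simple pyridine ring, a phenyl ring bearing an amine or a carboxylic acid, or a bicyclic group with its ring nitrogen placed elsewhere.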